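From 4-chlorobenzyl to 3-hydroxypropyl: a small expected step

This account rests on a few compounds, and the source may have more. Where it says the series, first, only, none or still open, it means among the compounds named here.

In a functional assay on RAW264.7 cells (Mus musculus) for inhibition, read by Griess assay, with stated times of 2 h and 24 h (a higher number here means a weaker inhibitor, a lower number a stronger inhibitor), compound 3 `COc1ccc([C@@H]2CC(=O)c3c(O)cc(OCc4cn(Cc5ccc(Cl)cc5)nn4)cc3O2)cc1O` gives 17800 nM. Compound 1 `COc1ccc([C@@H]2CC(=O)c3c(O)cc(OCc4cn(C5CCCC5)nn4)cc3O2)cc1O` gives 10500 nM and compound 2 `C#CCOc1cc(O)c2c(c1)O[C@H](c1ccc(OC)c(O)c1)CC2=O` gives 20900 nM. All three numbers lie within the usual scatter of one another, so compound 3 stands level with both. The change to compound 4 `COc1ccc([C@@H]2CC(=O)c3c(O)cc(OCc4cn(CCCO)nn4)cc3O2)cc1O` is 2-hydroxyethyl in place of 4-chlorophenyl on a saturated chain carbon bound to an aromatic nitrogen; cut one bond further out, 4-chlorobenzyl gives way to 3-hydroxypropyl. The closest evidence is a 1.7-fold higher number from compound 1 to compound 3 (0.23 log units; within the scatter), a swap on the same aromatic nitrogen. A second swap, a 2.0-fold higher number from compound 1 to compound 2 (0.30 log units; within the scatter), puts ethynyl in place of 1-cyclopentyl-1H-1,2,3-triazol-4-yl. Among the measured compounds shown here, no measured compound carries a 3-hydroxypropyl group. The expected change is a 1.2-fold lower number from compound 3 to compound 4 (0.07 log units; within the scatter), no step beyond the scatter. For compound 4 the estimate is 15000 nM, with an expected range of 7000 nM to 33000 nM.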

Compound 4, half-maximal inhibitory concentration: 16700 nM
Compound 4: the middle estimate sits 1.1-fold (0.05 log units) below what was measured; the measured number falls inside the stated range.
By their numbers in this assay, from the lowest: compounds 1, 4, 3 and 2 (each within the scatter of the next).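

In this assay, an open chain without a ring stands level with both ring-bearing groups on this aromatic nitrogen: 3-hydroxypropyl replaces 4-chlorobenzyl (a 1.1-fold lower number from compound 3 to compound 4 (0.03 log units; within the scatter)) and cyclopentyl (a 1.6-fold higher number from compound 1 to compound 4 (0.20 log units; within the scatter)). The whole 1-(3-hydroxypropyl)-1H-1,2,3-triazol-4-yl group also stands level with ethynyl (a 1.3-fold lower number from compound 2 to compound 4 (0.10 log units; within the scatter)). No evidence here accounts for these results. The compounds shown leave open whether a chain ending in an amine or a carboxylic acid would move the number beyond the scatter. Going by these compounds, a longer chain remains equally open.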